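Swapping Benzylsulfanyl for Dimethylamino on the Shared Core

The source may report more compounds than this note shows. Statements on the series, on what has been measured and on what is new or still open speak of the compounds shown alone.

Compound 1, `CSc1nccc2c1ncn2C1O[C@H](CO)[C@@H](O)[C@H]1O`, gives 24% in a functional assay (Homo sapiens) for inhibition of Nucleic Acid, tested at 100 uM; a higher number here means more inhibition at the concentration tested (going by the name of the read-out), a lower number less inhibition.
Compound 2, `OC[C@H]1OC(n2cnc3c(NCc4ccccc4)nccc32)[C@H](O)[C@@H]1O`, gives 32% in this assay.
Compound 3, `OC[C@H]1OC(n2cnc3c(SCc4ccccc4)nccc32)[C@H](O)[C@@H]1O`, gives 30% in this assay.

Compound 3 holds the second highest of these three numbers: its nearest neighbour is compound 2, with a number 2 percentage points lower from compound 2 to compound 3 (within the scatter), and its furthest is compound 1, with a number 6 percentage points higher from compound 1 to compound 3 (within the scatter). Compound 4, `CN(C)c1nccc2c1ncn2C1O[C@H](CO)[C@@H](O)[C@H]1O`, differs from compound 3 in one place: dimethylamino in place of benzylsulfanyl on an aromatic carbon. All three measured steps alter the group at this same aromatic carbon or within that group, and each stayed within the scatter, including a number 8 percentage points higher from compound 1 to compound 2 (within the scatter). The expected step is therefore a number 4 percentage points lower from compound 3 to compound 4 (within the scatter), nothing beyond the scatter. Compound 4 is estimated at 26%, between 12% and 40%.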

Compound 4, a percentage reported as inhibition, at one concentration (the size of the read-out at that concentration, not a potency): 0%
The estimate for compound 4 lay 26 percentage points above the measured number; measured number outside the range, below it.
By their numbers in this assay, from the lowest: compound 4; then compounds 1, 3 and 2 (each within the scatter of the next).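

Dimethylamino is the first group at this aromatic carbon to shift the number beyond the scatter, with a number 30 percentage points lower from compound 3 to compound 4 (beyond the scatter) and a number 32 percentage points lower from compound 2 to compound 4 (beyond the scatter) in this assay. Loss of the phenyl ring cannot be the whole story: methylsulfanyl has no ring either, yet there is a number 24 percentage points lower from compound 1 to compound 4 (beyond the scatter) as well, and benzylamino shows that a nitrogen on this carbon can go with a value like the others. Nothing available explains the drop. From the compounds shown here alone, whether a plain amino group or methylamino would behave like dimethylamino or like benzylamino remains open.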